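The compounds below may be only part of what the source reports. "The series", "measured", "known", "first", "only" and "open" are said of these compounds alone.

Measured so far:
compound 1 `CCN(Cc1ccccc1)C(=O)C1CCN(S(=O)(=O)c2ccc(OC)c(OC)c2)CC1`, 57%
compound 2 `CCN(Cc1ccccc1)C(=O)C1CCN(S(=O)(=O)c2cccc3c2OCCO3)CC1`, 53%
compound 3 `CCN(Cc1ccccc1)C(=O)C1CCN(S(=O)(=O)c2ccc(C(F)(F)F)nc2)CC1`, "not determined" (no result reported)

In a functional assay on CHO cells for positive allosteric modulation of muscarinic acetylcholine receptor M5 (Homo sapiens), read by calcium flux (a lower number here means a smaller maximal response, a higher number a larger maximal response), compound 1 gives 57% and compound 2 gives 53%; the step of a number 4 percentage points lower from compound 1 to compound 2 (within the scatter) lies within the scatter. Going by these compounds, compound 3 stands without a number in this assay, so its own level is unknown.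

Compound 4 `CCN(Cc1ccccc1)C(=O)C1CCN(S(=O)(=O)c2ccc3[nH]ncc3c2)CC1` differs from compound 3 by 1H-indazol-5-yl in place of 6-(trifluoromethyl)pyridin-3-yl on a sulfonyl sulfur. For the measured compounds named here, the only measured step, from compound 1 to compound 2, also exchanges the aryl group on the sulfonyl sulfur and was small, a number 4 percentage points lower from compound 1 to compound 2 (within the scatter), which suggests such exchanges need not move this assay beyond the scatter. With no value for compound 3, the estimate rests on compounds 1 and 2. Compound 4 is therefore expected to give about 55% in this assay, within 35% to 75%.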

Compound 4, largest response reached (reported as percent of maximum), in percent of the reference or control that the assay uses: 86%
Beside the measured number, compound 4's estimate is 31 percentage points below it; measured number outside the range, above it.
By their numbers in this assay, from the lowest: compounds 2 and 1 (each within the scatter of the next); then compound 4.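

On a sulfonyl sulfur, the aryl group is not always a silent exchange in this assay: 1H-indazol-5-yl gives a number 33 percentage points higher from compound 2 to compound 4 (beyond the scatter) and a number 29 percentage points higher from compound 1 to compound 4 (beyond the scatter). The earlier exchange between the two oxygen-bearing aryl groups showed no such separation, so this place can respond strongly to the group it carries. No measurement shown accounts for the size of these steps.

Compound 3 still has no number, so 1H-indazol-5-yl cannot be set against 6-(trifluoromethyl)pyridin-3-yl. Going by these compounds, whether an amine or a carboxylic acid on the aryl group would keep this higher maximal response remains open.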